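The source may report more compounds than this note shows. Statements on the series, on what has been measured and on what is new or still open speak of the compounds shown alone.

In an ADME assay on HepG2 cells (Homo sapiens) for cytotoxicity (on this read-out lower numbers stand for an effect already at smaller amounts and higher numbers for an effect only at larger amounts of compound), the measured compounds read as follows

- Compound 1 `Cc1ccc(S(=O)(=O)N[C@@H](CC(=O)NC(C)(C)C)C(=O)NCCNC(=O)c2ccccc2)cc1` gives > 11000 nM as a limit of the assay
- Compound 2 `Cc1ccc(S(=O)(=O)N[C@@H](CC(=O)NC(C)(C)C)C(=O)NCCNC(=O)c2ccccc2Cl)cc1` gives > 11000 nM as a limit of the assay
- Compound 3 `COc1cc(OC)cc(C(=O)NCCNC(=O)[C@H](CC(=O)NC(C)(C)C)NS(=O)(=O)c2ccc(C)cc2)c1` gives > 11000 nM as a limit of the assay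

Compound 3 therefore has a limit and no number, and it shares that position with the others, as the limit of > 11000 nM in this assay, at which 3 of the 3 values shown sit, shows.

Compound 4 `Cc1ccc(S(=O)(=O)N[C@@H](CC(=O)NC(C)(C)C)C(=O)NCCNS(=O)(=O)c2ccccc2)cc1` differs from compound 3 by phenylsulfonyl in place of (3,5-dimethoxyphenyl)carbonyl on an amine nitrogen and carries phenylsulfonyl in place of (3,5-dimethoxyphenyl)carbonyl on an amine nitrogen. Among the measured compounds shown here, three measured steps bear on this only loosely: a step that the two limits leave unreadable from compound 1 to compound 2 and a step that the two limits leave unreadable from compound 1 to compound 3 and a step that the two limits leave unreadable from compound 2 to compound 3 all have no readable size. None of them replaces the carbonyl itself. With no size to carry over, no change beyond the scatter is expected in this assay and no direction is favoured, so the expected step is a step that the limit leaves unreadable from compound 3 to compound 4 in estimate. For compound 4 the estimate is 12000 nM with an expected range of 7000 nM to 25000 nM and most likely another limit.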

Compound 4, half-maximal effective concentration: > 11000 nM
Compound 4 gave a limit, no number; the forecaster's own chance of this, stated with the estimate: 90%; the middle value is on the limit's open side.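

Compound 4 gives only a limit in this assay, as do compound 1, compound 2 and compound 3, so no step among them can be read: the limit of > 11000 nM in this assay, at which 4 of the 4 values shown sit.

The compounds shown leave open what concentration any of them needs for an effect, and whether phenylsulfonyl in place of a carbonyl-linked group changes that at all.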